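The compounds below may be only part of what the source reports. "The series", "measured", "known", "first", "only" and "open" are said of these compounds alone.

Among the measured compounds shown here, compound 1 `COc1cccc(C(=O)N(C)/N=C/c2ccc(OC)c(OC)c2)c1` stands lowest of the three measured members in a functional assay on the whole organism (strain A/J) for inhibition, with Mus musculus as the target, with stated times of 1 h and 18 h, at a dose of 100 umol/kg by the oral route (on this read-out lower numbers stand for less inhibition and higher numbers for more inhibition at the one dose given (going by the name of the read-out)), where compound 1 gives 70%. Compound 2 `COc1ccc(/C=N/N(C)c2ncnc3ccccc23)cc1OC` gives 82% and compound 3 `COc1ccc(/C=N/N(C)C(=O)c2ccc(OC)c(OC)c2)cc1OC` gives 92%, both beyond the scatter above compound 1. Compound 4 `COc1ccc(/C=N/N(C)C(=O)c2ccccc2)cc1OC` differs from compound 1 by hydrogen in place of methoxy on an aromatic carbon. For the measured compounds named here, the only measured single-point step runs the other way, adding a methoxy: a number 22 percentage points higher from compound 1 to compound 3 (beyond the scatter). Taking away the remaining methoxy is therefore expected to move the read-out downward, by a modest amount, though no direct precedent exists. The step expected for this change is a number 12 percentage points lower from compound 1 to compound 4 (beyond the scatter). Compound 4 is estimated at 58%, with a likely range from 40% to 76%.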

Compound 4, a percentage reported as inhibition, in the whole organism at one dose (the size of the read-out at that dose, not a potency): 58%
The estimate for compound 4 equals the measured number at the digits printed; the range from low to high includes it.
By their numbers in this assay, from the lowest: compound 4; then compound 1; then compounds 2 and 3 (each within the scatter of the next).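

In this assay the change from 3-methoxyphenyl to phenyl gives a number 12 percentage points lower from compound 1 to compound 4 (beyond the scatter) and shows that taking away a methoxy on this aromatic carbon lowers the read-out at this one dose. Only the addition of a methoxy had been seen before, as a number 22 percentage points higher from compound 1 to compound 3 (beyond the scatter) on the upward side, so compound 1 now has a step beyond the scatter in each direction. Nothing available explains the drop.

Among the compounds shown here, still open is whether methoxy is the only group that holds the read-out at this place, since an amine, a hydroxyl or a longer ethoxy chain there could behave differently.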